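The compounds below may be only part of what the source reports. "The series", "measured", "known", "first", "only" and "open" are said of these compounds alone.

Measured in a functional assay on WM1361 cells (Homo sapiens) for antiproliferative activity, read by MTT assay, with a stated time of 48 h; on this read-out higher numbers stand for weaker inhibition and lower numbers for stronger inhibition:
compound 1 `Cc1ccc(-c2cc(NC(=O)c3ccc(Cl)nc3)n[nH]2)cc1` gives 16700 nM
compound 2 `COc1ccc(C(=O)Nc2cc(-c3ccc(C)cc3)[nH]n2)cn1` gives 24900 nM
compound 3 `O=C(Nc1cc(-c2ccc(Br)cc2)[nH]n1)c1cccnc1Cl` gives 18500 nM

Compound 4 `COc1ncccc1C(=O)Nc1cc(-c2ccc(Br)cc2)[nH]n1` is not yet measured. It differs from compound 3 by methoxy in place of chloro on an aromatic carbon. The same kind of change separates compound 1 from compound 2: methoxy in place of chloro on an aromatic carbon. The two places are not identical: in the measured pair the group enters para to a large group, whereas in compound 4 it enters ortho to a large group. The measured step was a 1.5-fold higher number from compound 1 to compound 2 (0.17 log units; within the scatter). The difference between the cores of compound 1 and compound 3 is not broken down here, and their values lie within the scatter of each other.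

Compound 4 is expected near 25000 nM because a 1.5-fold higher number from compound 1 to compound 2 (0.17 log units; within the scatter) stayed within the scatter. The expected range for compound 4 runs from 12000 nM to 50000 nM. The expected step is a 1.4-fold higher number from compound 3 to compound 4 (0.13 log units; within the scatter), resting on the same kind of change in the measured pair.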

Compound 4, half-maximal inhibitory concentration: 31000 nM
For compound 4 the middle estimate is 1.2-fold (0.09 log units) below the measured one; low and high end bracket the measured number.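

In this assay, methoxy in place of chloro, ortho to a large group and next to the ring nitrogen, gives a 1.7-fold higher number from compound 3 to compound 4 (0.22 log units; within the scatter). Set beside the earlier step, the change carries over between the two cores with no detectable difference: the same change on two cores in this assay, a 1.5-fold higher number (0.17 log units; within the scatter) from compound 1 to compound 2 and a 1.7-fold higher number (0.22 log units; within the scatter) from compound 3 to compound 4, 1.1-fold (0.05 log units) apart, within the scatter of two such steps. Within the data shown here, this shows only that the change stays within the scatter on both cores; two pairs give no rule for the whole series and do not show that methoxy and chloro are interchangeable on other cores.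

Open, on these data alone, is whether an amine, a carboxylic acid or a longer chain such as ethoxy at this carbon would move the number beyond the scatter. Also open, as far as these compounds go, is what bromo in place of methyl does on its own.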